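A few compounds are considered here, and "the series" means these few. Any claim that something is new, unique, unknown or untested is made for them only; others in the source may bear on it.

Measured compounds:
Compound 1 `COc1ccc(/C=C\C(=O)O)c(OCc2cn(-c3ccccc3F)nn2)c1CC=C(C)C` – 14500 nM
Compound 2 `COc1ccc(/C=C\C(=O)O)c(OCc2cn(-c3cccc(C#N)c3)nn2)c1CC=C(C)C` – 26800 nM
Compound 3 `COc1ccc(/C=C\C(=O)O)c(OCc2cn(-c3ccc(CO)cc3)nn2)c1CC=C(C)C` – 19300 nM

In a functional assay on COLO 205 cells (Homo sapiens) for cytotoxicity, read by MTT assay, with a stated time of 24 h (on this read-out higher numbers stand for weaker inhibition and lower numbers for stronger inhibition), compound 1 gives the smallest of the three numbers, yet neither gap reaches beyond the scatter: a 1.8-fold higher number from compound 1 to compound 2 (0.27 log units; within the scatter) and a 1.3-fold higher number from compound 1 to compound 3 (0.12 log units; within the scatter). Compound 4 `COc1ccc(/C=C\C(=O)O)c(OCc2cn(-c3ccccc3C(=O)N3CCC(O)C3)nn2)c1CC=C(C)C` differs from compound 1 by (3-hydroxypyrrolidin-1-yl)carbonyl in place of fluoro on an aromatic carbon. The three measured steps all exchange the group carried on the phenyl ring attached to the aromatic nitrogen, and every one of them stayed within the scatter, as a 1.4-fold lower number from compound 2 to compound 3 (0.14 log units; within the scatter) also shows. On that basis the step of a 1.2-fold higher number from compound 1 to compound 4 (0.07 log units; within the scatter) is expected to be small, with no direction beyond the scatter. Compound 4 is therefore estimated at 17000 nM, within a range from 7000 nM to 45000 nM.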

Compound 4, half-maximal inhibitory concentration: 25400 nM
Estimate against measurement, compound 4: 1.5-fold (0.17 log units) below; low and high end bracket the measured number.
By their numbers in this assay, from the lowest: compounds 1, 3, 4 and 2 (each within the scatter of the next).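

Placing (3-hydroxypyrrolidin-1-yl)carbonyl in place of fluoro gives a 1.8-fold higher number from compound 1 to compound 4 (0.24 log units; within the scatter) in this assay. The earlier steps shown here exchanged one substituted phenyl group for another, whereas this one replaces a single fluorine with a group of 8 heavy atoms that brings a non-aromatic ring and a hydrogen-bond donor. Even so, on this aromatic carbon, ortho to a large group, the step stays within the scatter. From the compounds shown here alone, whether an amine or a carboxylic acid at this place would give a step beyond the scatter remains open. No measurement at hand gives a reason for this result.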